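From compound 3 to compound 4: methoxy enters

The compounds below may be only part of what the source reports. "The series", "measured", "known", "first", "only" and "open" are said of these compounds alone.

Measured in a functional assay on HL-60 cells (Homo sapiens) for antiproliferative activity, read by MTT assay, with a stated time of 48 h; a higher number here means a weaker inhibitor, a lower number a stronger inhibitor:
compound 1 `O=C(CCCCCC(=O)Nc1ccc(O)c(C(=O)Nc2ccccc2)c1)NO` gives 20300 nM
compound 2 `C#Cc1cccc(NC(=O)c2cc(NC(=O)CCCCCC(=O)NO)ccc2O)c1` gives the limit > 100000 nM
compound 3 `C#Cc1cccc(NC(=O)c2cccc(NC(=O)CCCCCC(=O)NO)c2)c1` gives the limit > 100000 nM

Compound 3 has no number, only (the limit of > 100000 nM in this assay, at which 2 of the 3 values shown sit). Compound 4 `C#Cc1cccc(NC(=O)c2cc(NC(=O)CCCCCC(=O)NO)ccc2OC)c1` differs from it by methoxy in place of hydrogen on an aromatic carbon.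

For the measured compounds named here, two measured steps bear on this change. Ethynyl in place of hydrogen on an aromatic carbon gave an at least 4.9-fold higher number from compound 1 to compound 2 (0.69 log units; beyond the scatter), and compound 4 keeps that ethynyl. Hydrogen in place of hydroxy on an aromatic carbon gave a step that the two limits leave unreadable from compound 2 to compound 3, so the one step at the carbon that takes the methoxy offers no size to carry over.

No clear gain is therefore expected in this assay, and compound 4 will most likely be reported as a limit again. The expected step is a number no higher from compound 3 to compound 4 (the limit leaves the size open). For compound 4 the estimate is 100000 nM, with an expected range from 30000 nM to 300000 nM.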

Compound 4, half-maximal inhibitory concentration: 7100 nM
Compound 4: middle estimate off by 14-fold (1.15 log units), on the high side, and the stated range ends above it.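

In this assay, methoxy in place of hydrogen on this aromatic carbon gave an at least 14-fold lower number from compound 3 to compound 4 (1.14 log units; beyond the scatter), and methyl in place of hydrogen on the oxygen gave an at least 14-fold lower number from compound 2 to compound 4 (1.14 log units; beyond the scatter). Neither hydrogen nor hydroxy on this carbon, ortho to a large group and para to a large group, yields a readable value with the ethynyl group present, whereas methoxy does, so the ethynyl group does not by itself rule out a measured value. Both steps start from a limit, which makes them minimum sizes, and the step between the hydrogen and hydroxy compounds cannot be read: the limit of > 100000 nM in this assay, at which 2 of the 4 values shown sit.

As far as these compounds go, it remains open whether ethoxy or an amine on this carbon would give a measured value as well. From the compounds shown here alone, it is also open whether methoxy would lower the number in the same way on the core of compound 1, which lacks the ethynyl group.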